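Lengthening the chain on the core nitrogen of compound 2

This account rests on a few compounds, and the source may have more. Where it says the series, first, only, none or still open, it means among the compounds named here.

Compound 2 `O=C1Nc2ccccc2/C1=C\c1c(Cl)n(Cc2ccccc2)c2ccccc12` is tested in a functional assay on cells (Cancer cell lines, Homo sapiens) for cytotoxicity, with a stated time of 48 h (a higher number here means a weaker inhibitor of growth, a lower number a stronger inhibitor of growth), where compound 2 gives 60300 nM. Among the three measured compounds this is the highest number. Its nearest neighbour is compound 1 `COc1cc2c(/C=C3/C(=O)Nc4ccc(O)cc43)c(Cl)n(Cc3cc(OC)c(OC)c(OC)c3)c2cc1C`, which in this assay gives 49000 nM, a gap that lies within the usual scatter. Furthest away is compound 3 `COc1cc2c(/C=C3/C(=O)Nc4ccc(Cl)cc43)c(Cl)n(Cc3cc(OC)c(OC)c(OC)c3)c2cc1C`, which gives 5620 nM; the only measured step, an 8.7-fold lower number from compound 1 to compound 3 (0.94 log units; beyond the scatter), concerns a group on an aromatic carbon and not the chain on the aromatic nitrogen, so it says little about the change considered here. Compound 4 `O=C1Nc2ccccc2/C1=C\c1c(Cl)n(CCCc2ccccc2)c2ccccc12` differs from compound 2 by phenethyl in place of phenyl on a saturated chain carbon bound to an aromatic nitrogen. Among the compounds with values here, no measured pair shows the effect of lengthening this chain, so there is nothing to argue for a shift in either direction, and the step of a 1.2-fold lower number from compound 2 to compound 4 (0.08 log units; within the scatter) is expected to stay within the scatter. Compound 4 is therefore estimated to give 50000 nM, with a range from 15000 nM to 160000 nM.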

Compound 4, concentration for total growth inhibition: 60300 nM
Compound 4: the middle estimate sits 1.2-fold (0.08 log units) below what was measured; the measured number falls inside the stated range.
By their numbers in this assay, from the lowest: compound 3; then compounds 1, 2 and 4 (each within the scatter of the next).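

In this assay, within the data shown here, this is the first reading of the chain on the core nitrogen, and replacing phenyl with phenethyl on a saturated chain carbon bound to an aromatic nitrogen gives no change at the digits printed from compound 2 to compound 4 (within the scatter), so the same difference read as benzyl to 3-phenylpropyl leaves the number where it was. This position therefore accepts the added chain length here without a detectable gain or loss in growth inhibition, although this single pair speaks only for the unsubstituted core of compound 2. Nothing available here offers an explanation for this flat result.

As far as these compounds go, whether an amine or a carboxylic acid on this chain would move the number remains open. So does whether the same lengthening would behave alike on the core of compound 3, which carries chloro and methoxy groups.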